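Sulfonyl hydrazides against indoleamine 2,3-dioxygenase 1: working notes

The source may hold more compounds than are shown below. What is called first, only, known or untested is meant among the compounds shown, and "the series" means these compounds.

Measured in an assay on HeLa cells for inhibition of Indoleamine 2,3-dioxygenase 1 (Homo sapiens), read by spectrophotometry, with a stated time of 24 h; a higher number here means that more compound is needed for the effect, a lower number that less compound is needed:

compound 1, `CC(=O)Nc1ccc(S(=O)(=O)NNc2ccc(C)cc2)cc1`: 1170 nM
compound 2, `CC(=O)Nc1ccc(S(=O)(=O)NNc2ccc(F)cc2)cc1`: 609 nM
compound 3, `CC(=O)Nc1ccc(S(=O)(=O)NNc2ccc(Br)c(F)c2)cc1`: 187 nM

Compound 2 and compound 1 differ only by methyl in place of fluoro on an aromatic carbon; the step of a 1.9-fold higher number from compound 2 to compound 1 (0.28 log units; within the scatter). Compound 3 gives the lowest number of the three, and its values and those of compound 2 stand apart beyond the scatter; how the core of compound 3 differs from the core of compound 2 is not broken down here.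

Compound 4, `CC(=O)Nc1ccc(S(=O)(=O)NNc2ccc(Br)c(C)c2)cc1`, awaits measurement in this assay. It differs from compound 3 by methyl in place of fluoro on an aromatic carbon. Within the data shown here, this is the same kind of change as the one from compound 2 to compound 1, but the place differs: here the carbon is ortho to a bromo group and meta to a large group, there it was para to a large group.

The step from compound 3 to compound 4 is expected to be about a 1.6-fold higher number from compound 3 to compound 4 (0.21 log units; within the scatter), resting on the earlier step of a 1.9-fold higher number from compound 2 to compound 1 (0.28 log units; within the scatter). Compound 4 is therefore estimated at 300 nM, expected between 150 nM and 650 nM.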

Compound 4, half-maximal effective concentration: 130 nM
For compound 4 the middle estimate is 2.3-fold (0.36 log units) above the measured one; measured number outside the range, below it.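

In this assay the new step is a 1.4-fold lower number from compound 3 to compound 4 (0.16 log units; within the scatter), and although each step alone lies within the scatter, the two do not agree across the cores: the same change on two cores in this assay, a 1.9-fold higher number (0.28 log units; within the scatter) from compound 2 to compound 1 and a 1.4-fold lower number (0.16 log units; within the scatter) from compound 3 to compound 4, 2.8-fold (0.44 log units) apart, beyond the scatter of two such steps This shows that methyl in place of fluoro on an aromatic carbon cannot be carried from the core of compound 2 to the core of compound 3 as a fixed increment in this series. Among these compounds, it does not show why the steps part, and it rests on only two steps, with the change also sitting at a different place on the second core, ortho to a bromo group and meta to a large group, and neither step on its own separates methyl from fluoro.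

Open, going by these compounds, is whether the bromo group or the place of the change accounts for the gap between the steps. Also open, on these data alone, is how an amine, a carboxylic acid or a longer chain on the same carbon would read on either core.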